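The source may hold more compounds than are shown below. What is called first, only, known or untested is meant among the compounds shown, and "the series" means these compounds.

Among the measured compounds shown here, in an ADME assay (liver) for pharmacokinetics, with Liver microsome (Homo sapiens) as the target, using microsomes (on this read-out lower numbers stand for a shorter-lived compound and higher numbers for a longer-lived compound), compound 1 `CCOc1cc(NC(=O)C2(NC(=O)c3ccc4c(C5CCCC5)c(-c5ncc(Cl)cn5)n(C)c4c3)CCC2)ccc1/C=C/C(=O)OCOP(=O)(O)O` gives 0.167 h, the only exact number available so far. The one other result comes from compound 2 `CCOc1cc(NC(=O)C2(NC(=O)c3ccc4c(C5CCCC5)c(-c5ncc(Cl)cn5)n(C)c4c3)CCC2)ccc1/C=C/C(=O)OCC(C)C`, which shares the core of compound 1 and differs in a single group. Compound 2 reads > 5 h, and this is a limit of the assay, not a number.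

Compound 3 `CCOc1cc(NC(=O)C2(NC(=O)c3ccc4c(C5CCCC5)c(-c5ncc(Cl)cn5)n(C)c4c3)CCC2)ccc1/C=C/C(=O)OCCOc1ccccc1` has not yet been measured. Its change from compound 1 falls at the same place: a group of 8 heavy atoms (7 carbon, 1 oxygen; one six-membered aromatic ring of carbon only) in place of a group of 5 heavy atoms (4 oxygen, 1 phosphorus; no ring), on a saturated chain carbon bound to an oxygen next to a carbonyl group. For the measured compounds named here, the same phosphorus-containing group leaves in both cases, so the single measured step, an at least 29-fold higher number from compound 1 to compound 2 (1.47 log units; beyond the scatter), is the only guide here. Going by the values given here, that step is large, but the group entering compound 3 differs from the one in compound 2, so the guide is loose. A rise beyond the scatter in this assay is therefore expected, though its size is uncertain. The expected change is a 15-fold higher number from compound 1 to compound 3 (1.18 log units; beyond the scatter). For compound 3, the estimated half-life is 2.5 h, with an expected range from 0.5 h to 8 h.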

Compound 3, half-life: > 5 h
Compound 3: no number, only a limit; the forecaster's own chance of this, stated with the estimate: 35%; at least 2.0-fold (0.30 log units) between middle value and limit.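

In this assay, a second, quite different group at this place, on a saturated chain carbon bound to an oxygen next to a carbonyl group, gives an at least 29-fold higher number from compound 1 to compound 3 (1.47 log units; beyond the scatter). The large rise seen with isopropyl is therefore not unique to that group, since phenoxymethyl, which brings a six-membered aromatic ring and more heavy atoms, also gives a large rise when it replaces the phosphorus-containing group. The result for compound 3, > 5 h, is a limit of the assay and not a number, and the step between compound 2 and compound 3 cannot be read because both results are limits: the limit of > 5 h in this assay, at which 2 of the 3 values shown sit.

The compounds shown leave open how much longer-lived compound 3 really is, and whether isopropyl and phenoxymethyl differ at all in this read-out. As far as these compounds go, it also remains open whether the rise follows from losing the phosphorus-containing group whatever replaces it, or whether a plain methyl or a chain ending in an amine or a carboxylic acid at the same place would give a different half-life.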